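Opening a Bicyclic Amine Into a Flexible Chain

The compounds below may be only part of what the source reports. "The series", "measured", "known", "first", "only" and "open" are said of these compounds alone.

Three compounds sharing one core were measured in an assay on isolated protein for inhibition of DNA topoisomerase 1 (Homo sapiens), with a stated time of 15 min; a higher number here means a weaker inhibitor, a lower number a stronger inhibitor. Compound 2 `O=C(O)c1cn(Cc2ccc(-c3ccccc3)cc2)c2cc(N3CC4CNCC4C3)c(F)cc2c1=O` gives 33300 nM, the lowest of the three numbers. Compound 1 `NC[C@@H]1CCN(c2ccc3c(=O)c(C(=O)O)cn(Cc4ccc(-n5cccn5)cc4)c3c2)C1` gives 61000 nM, a number within the scatter of that of compound 2. Within the data shown here, compound 3 `O=C(O)c1cn(Cc2ccc(-n3cccn3)cc2)c2cc(N3CC4CNCC4C3)c(F)cc2c1=O` gives 173000 nM; the only single-point step in the set, a 5.2-fold higher number from compound 2 to compound 3 (0.72 log units; beyond the scatter), concerns a change at a different part of the molecule. Compound 4 `CNCCCCNc1cc2c(cc1F)c(=O)c(C(=O)O)cn2Cc1ccc(-c2ccccc2)cc1` differs from compound 2 at the amine side: a group of 7 heavy atoms (5 carbon, 2 nitrogen; no ring) in place of a group of 8 heavy atoms (6 carbon, 2 nitrogen; 2 five-membered non-aromatic rings with 1 hetero atom each), on an aromatic carbon. Among the measured compounds shown here, no measured step bears on that change, since compound 1 differs from compound 2 in more than one place and compound 3 in another place entirely; they only mark out the spread of numbers seen so far. Lacking a direct precedent, the analysis expects a step of modest size, a 1.7-fold higher number from compound 2 to compound 4 (0.22 log units; within the scatter), most likely toward a higher number. Compound 4 is therefore estimated at 55000 nM, with a range from 15000 nM to 180000 nM.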

Compound 4, half-maximal inhibitory concentration: 88300 nM
Compound 4: middle estimate off by 1.6-fold (0.21 log units), on the low side; the measured number falls inside the stated range.
By their numbers in this assay, from the lowest: compounds 2, 1, 4 and 3 (each within the scatter of the next, the first and the last beyond it).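

Among these compounds, compound 4 gives the first direct reading at the amine side, on the aromatic carbon ortho to the fluoro group. In this assay, replacing the two-ring amine with the open (4-(methylamino)butyl)amino chain gives a 2.7-fold higher number from compound 2 to compound 4 (0.42 log units; beyond the scatter), so this position does affect the number, and the ring system is not needed for measurable inhibition at this level. No measurement shown accounts for the step.

The compounds shown do not separate the loss of the rings from the length of the chain or its terminal methylamino group, a question that a shorter or longer chain, a terminal primary amine or a piperazine could address. Also open, going by these compounds, is whether the same exchange would give a step of similar size with 1H-pyrazol-1-yl in place of phenyl.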